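Ethyl on the aromatic nitrogen of compound 2

The source may report more compounds than this note shows. Statements on the series, on what has been measured and on what is new or still open speak of the compounds shown alone.

Measured compounds:
- compound 1 `COc1cc(C(=O)c2cccc3[nH]ccc23)cc(OC)c1OC` gives 49.1 nM
- compound 2 `COc1cc(C(=O)c2ccc3[nH]ccc3c2)cc(OC)c1OC` gives 88 nM
- compound 3 `COc1cc(C(=O)c2cccc3c2ccn3C)cc(OC)c1OC` gives 21.6 nM

In a functional assay on MKN-45 cells (Homo sapiens) for inhibition, with a stated time of 72 h (on this read-out lower numbers stand for stronger inhibition and higher numbers for weaker inhibition), compound 2 gives 88 nM and this lies within the scatter of compound 1 at 49.1 nM on the same read-out. Only compound 3 at 21.6 nM lies beyond the scatter from compound 2, on the lower side.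

The next compound, compound 4 `CCn1ccc2cc(C(=O)c3cc(OC)c(OC)c(OC)c3)ccc21`, differs from compound 2 in one place, with ethyl in place of hydrogen on an aromatic nitrogen. Among the measured compounds shown here, the one measured step that bears on this is a 2.3-fold lower number from compound 1 to compound 3 (0.36 log units; beyond the scatter) for methyl in place of hydrogen on an aromatic nitrogen, a modest change that goes beyond the scatter. For the measured compounds named here, that step was measured on compound 1 rather than on compound 2, and no ethyl group has yet been measured in this set, so it is only a rough guide.

A modest move towards a lower number is therefore expected, and the expected size is a 2.0-fold lower number from compound 2 to compound 4 (0.29 log units; within the scatter) in this assay as a working figure. For compound 4 the estimated value is 45 nM with an expected range from 15 nM to 130 nM for the measurement to come.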

Compound 4, half-maximal inhibitory concentration: 31 nM
Estimate against measurement, compound 4: 1.5-fold (0.16 log units) above; the range from low to high includes it.
By their numbers in this assay, from the lowest: compounds 3, 4, 1 and 2 (each within the scatter of the next, the first and the last beyond it).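

In this assay, ethyl in place of hydrogen on the aromatic nitrogen gives a 2.8-fold lower number from compound 2 to compound 4 (0.45 log units; beyond the scatter), so the change is now seen on compound 2 itself and with a group larger than methyl. Until now the only evidence at such a nitrogen was the methyl step, a 2.3-fold lower number from compound 1 to compound 3 (0.36 log units; beyond the scatter), and the new step runs in the same direction, so two different parent compounds now agree that replacing this hydrogen lowers the number, while the hydrogen itself is shown not to be needed for activity on this read-out in compound 2. Nothing available explains why the number falls with either group.

The compounds shown leave open how far this trend extends along the chain: a longer chain such as butyl, or a chain ending in an amine or a carboxylic acid, might lower the number further or reverse the step. They also leave open whether methyl on the nitrogen of compound 2 would differ at all from ethyl, and whether ethyl on the nitrogen of compound 1 would behave as it does here.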